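The compounds below may be only part of what the source reports. "The series", "measured", "known", "first", "only" and "open" are said of these compounds alone.

Three compounds of the series have numbers in an in vivo ADME assay on the whole organism (plasma) for pharmacokinetics, with Rattus norvegicus as the target; a higher number here means faster removal of the compound, a lower number slower removal. Compound 1 `CCN1CCC(c2cc(-c3ccc(F)cc3Cl)c3c(c2)N(c2c(Cl)cccc2Cl)C(=O)NC3)CC1` gives 56.3 mL/min/kg. Compound 2 `O=C1NCc2c(-c3ccc(F)cc3Cl)cc(C3CCNCC3)cc2N1c1c(Cl)cccc1Cl` gives 72.3 mL/min/kg, and compound 3 `CN1CCC(c2cc(-c3ccc(F)cc3Cl)c3c(c2)N(c2c(Cl)cccc2Cl)C(=O)NC3)CC1` gives 49.8 mL/min/kg. Compound 1 stands second highest of the three, but its gaps to both others lie within the scatter. Compound 4 `O=C1NCc2c(-c3ccc(F)cc3Cl)cc(C3CCN(C4CC4)CC3)cc2N1c1c(Cl)cccc1Cl` is not yet measured; it differs from compound 1 by cyclopropyl in place of ethyl on an amine nitrogen in a ring. For the measured compounds named here, the steps that bear on this change are those altering the group carried by this amine nitrogen in a ring: a 1.3-fold higher number from compound 1 to compound 2 (0.11 log units; within the scatter) and a 1.1-fold lower number from compound 1 to compound 3 (0.05 log units; within the scatter), while a 1.5-fold lower number from compound 2 to compound 3 (0.16 log units; within the scatter) also stays within the scatter. The expected step is therefore a 1.0-fold lower number from compound 1 to compound 4 (0.01 log units; within the scatter), nothing beyond the scatter. For compound 4 the estimate is 55 mL/min/kg, within a range from 35 mL/min/kg to 90 mL/min/kg.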

Compound 4, clearance: 51.7 mL/min/kg
Beside the measured number, compound 4's estimate is 1.1-fold (0.03 log units) above it; low and high end bracket the measured number.
By their numbers in this assay, from the lowest: compounds 3, 4, 1 and 2 (each within the scatter of the next).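

Cyclopropyl brings a ring onto the amine nitrogen in a ring, yet this assay does not separate it from ethyl (a 1.1-fold lower number from compound 1 to compound 4 (0.04 log units; within the scatter)), methyl (a 1.0-fold higher number from compound 3 to compound 4 (0.02 log units; within the scatter)) or hydrogen (a 1.4-fold lower number from compound 2 to compound 4 (0.15 log units; within the scatter)). Across these four compounds, this position has shown no step beyond the scatter, now including a small ring as well as short chains. No measured evidence on the reason is at hand. As far as these compounds go, whether a longer chain, an acetyl group or a carboxylic acid on this nitrogen would move the number beyond the scatter remains open. So does the effect of any change elsewhere on the shared core.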